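A few compounds are considered here, and "the series" means these few. Any claim that something is new, unique, unknown or untested is made for them only; others in the source may bear on it.

Compound 1, `COC(=O)C1=C(C)NC(=O)NC1c1cccs1`: 19%
Compound 2, `CCCOC(=O)C1=C(C)NC(=S)NC1c1ccco1`: 46%
Compound 3, `COC(=O)C1=C(C)N(C)C(=O)NC1c1cccs1`: 17%

In an assay on membranes from HEK293 cells for displacement of a labelled ligand from adenosine receptor A2b (Homo sapiens), read by scintillation counting, with a stated time of 30 min, tested at 1 uM (a higher number here means more inhibition at the concentration tested (going by the name of the read-out), a lower number less inhibition), compound 1 stands second highest of the three numbers. Its nearest neighbour is compound 3, where a number 2 percentage points lower from compound 1 to compound 3 (within the scatter). Compound 2 gives the highest number, but it differs from compound 1 in several places at once, the ester among them, so its value alone cannot be tied to any one change.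

Compound 4, `CCC(CC)OC(=O)C1=C(C)NC(=O)NC1c1cccs1`, differs from compound 1 in one place: pentan-3-yl in place of methyl on an oxygen next to a carbonyl group. Within the data shown here, no measured step changes only the ester; the one single change on record, from compound 1 to compound 3, stays within the scatter. The expectation for compound 4 is therefore a small rise in this assay, a number 9 percentage points higher from compound 1 to compound 4 (within the scatter), to an estimated 28%, within 10% to 50%.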

Compound 4, a percentage reported as inhibition, at one concentration (the size of the read-out at that concentration, not a potency): 6%
For compound 4 the middle estimate is 22 percentage points above the measured one; the measured number lies below the stated range.
By their numbers in this assay, from the lowest: compound 4; then compounds 3 and 1 (each within the scatter of the next); then compound 2.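

In this assay, among these compounds, the step of a number 13 percentage points lower from compound 1 to compound 4 (beyond the scatter) is the only single change at the ester on record, and it shows that this position responds to the group on the oxygen. Among the compounds shown here, the one earlier single change, a number 2 percentage points lower from compound 1 to compound 3 (within the scatter), lay elsewhere on the core and stayed within the scatter. Nothing measured here gives a reason for the drop with pentan-3-yl.

On these data alone, whether an ethyl group on that oxygen would stay near compound 1 or fall towards compound 4 remains open. So does the outcome with a free carboxylic acid in place of the ester.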